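The source may report more compounds than this note shows. Statements on the series, on what has been measured and on what is new or still open speak of the compounds shown alone.

Working notes on the selenocyanate carbamate series.

The three measured compounds are compound 1 `COc1ccc(OC(=O)Nc2ccc([Se]C#N)cc2)cc1`, compound 2 `CCCCOC(=O)Nc1ccc([Se]C#N)cc1` and compound 3 `CCCCCCOC(=O)Nc1ccc([Se][Se]c2ccc(NC(=O)OCCCCCC)cc2)cc1`. In a functional assay on MCF7 cells (Homo sapiens) for cytotoxicity, read by MTT assay, with a stated time of 72 h (on this read-out higher numbers stand for weaker inhibition of growth and lower numbers for stronger inhibition of growth), compound 2 gives 20200 nM. In the same assay compound 1 gives 48200 nM, and compound 3 gives 52900 nM. Compound 2 therefore holds the lowest of the three numbers; compound 1 sits nearest to it, and compound 3 furthest, both of these gaps falling beyond the usual scatter of this assay.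

The next member, compound 4 `CCCCCCOC(=O)Nc1ccc([Se]C#N)cc1`, is not yet measured. It differs from compound 2 by ethyl in place of hydrogen on a saturated chain carbon, four bonds along the chain from an oxygen next to a carbonyl group, which in plain terms lengthens the chain on the carbamate oxygen from butyl to hexyl while the selenocyanate and the shared core are kept. Among the compounds with values here, no measured pair shows this change in isolation: compound 3 carries a hexyl carbamate but also a diselenide bridge, so its value against compound 2 reflects two changes at once and cannot be assigned to the chain alone.

Within the data shown here, with no directly comparable step, the expectation for the chain extension is a change of no more than the scatter, in either direction, giving an estimated step of a 1.1-fold higher number from compound 2 to compound 4 (0.04 log units; within the scatter). On that basis compound 4 is estimated to give 22000 nM in this assay, within a range from 8000 nM to 60000 nM.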

Compound 4, concentration for total growth inhibition: 30500 nM
Compound 4: middle estimate off by 1.4-fold (0.14 log units), on the low side, and the stated range covers the measured number.
By their numbers in this assay, from the lowest: compounds 2, 4, 1 and 3 (each within the scatter of the next, the first and the last beyond it).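

Within the data shown here, compound 4 gives the first reading of the chain change on its own, with the selenocyanate and the shared core kept: in this assay the step is a 1.5-fold higher number from compound 2 to compound 4 (0.18 log units; within the scatter) and so butyl and hexyl on the carbamate oxygen cannot be told apart on this read-out. Ethyl in place of hydrogen on this saturated chain carbon, four bonds along the chain from an oxygen next to a carbonyl group, therefore leaves the number within the scatter, a finding that rests on this single pair and sets no pattern for the series. No supporting data bear on what lies behind this result.

The compounds shown leave open whether a longer chain such as octyl, or a branched chain such as isobutyl, would move the number beyond the scatter when the selenocyanate is kept. Among these compounds, they also leave open how a chain ending in an amine or a carboxylic acid would read in this assay, since every chain at this place so far is a plain alkyl chain.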